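The source may hold more compounds than are shown below. What is called first, only, known or untested is meant among the compounds shown, and "the series" means these compounds.

Compound 1 `CCCCOC(=O)NS(=O)(=O)c1sc(CC(C)C)cc1-c1ccc(Cn2cccn2)cc1`: 2.3 nM
Compound 2 `CCCCOC(=O)NS(=O)(=O)c1sc(CC(C)C)cc1-c1ccc(CN2CCCC2=O)cc1`: 3.5 nM
Compound 3 `CCCCOC(=O)NS(=O)(=O)c1sc(CC(C)C)cc1-c1ccc(C(=O)c2ccnn2C)cc1`: 3.4 nM

In an assay on membranes from uterus for displacement of a labelled ligand from Angiotensin type II receptor (Sus scrofa), with a stated time of 1.5 h (a lower number here means a stronger inhibitor, a higher number a weaker inhibitor), compound 1 gives 2.3 nM, the lowest of the three numbers, but the step of a 1.5-fold higher number from compound 1 to compound 2 (0.18 log units; within the scatter) and the step of a 1.5-fold higher number from compound 1 to compound 3 (0.17 log units; within the scatter) both lie within the scatter, so no order among compounds 1, 2 and 3 can be drawn. Between compounds 2 and 3 the step of a 1.0-fold lower number from compound 2 to compound 3 (0.01 log units; within the scatter) is likewise within the scatter. Each of these steps exchanges the whole group carried at the far end of the shared core of compound 1, and none of them moves the number appreciably.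

Compound 4 `CCCCOC(=O)NS(=O)(=O)c1sc(CC(C)C)cc1-c1ccc(Cn2ccc(C(F)(F)F)n2)cc1` differs from compound 1 by trifluoromethyl in place of hydrogen on an aromatic carbon. Among the measured compounds shown here, no measured step places a substituent on the ring of 1H-pyrazol-1-yl itself, so there is no direct precedent. For the measured compounds named here, the only guide is that three quite different groups in this region of the molecule all give numbers within the scatter of one another, which suggests the region tolerates variation. On that basis the step of a 1.3-fold higher number from compound 1 to compound 4 (0.12 log units; within the scatter) in this assay is expected to be small and not beyond the scatter, with no clear direction. Compound 4 is therefore estimated at 3 nM in this assay, within a range of 1 nM to 9 nM.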

Compound 4, inhibition constant: 9.5 nM
Estimate against measurement, compound 4: 3.2-fold (0.50 log units) below; measured number above the stated range.
By their numbers in this assay, from the lowest: compounds 1, 3 and 2 (each within the scatter of the next); then compound 4.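

In this assay, among the compounds shown here, the step of a 4.1-fold higher number from compound 1 to compound 4 (0.62 log units; beyond the scatter) is the first in this set to lie beyond the scatter, and it comes from trifluoromethyl on an aromatic carbon of the five-membered aromatic ring, two ring bonds from the ring atom that bears a large group. The other two new steps, a 2.8-fold higher number from compound 3 to compound 4 (0.45 log units; beyond the scatter) and a 2.7-fold higher number from compound 2 to compound 4 (0.43 log units; beyond the scatter), are also beyond the scatter, so compound 4 stands apart from all three earlier compounds, although only modestly, and the tolerance seen when whole groups were exchanged does not extend to this substituent on the 1H-pyrazol-1-yl ring. Nothing available bears on why the number rises with this change.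

On these data alone, it remains open whether the rise is particular to trifluoromethyl or would also appear with a smaller group such as methyl or a chlorine atom on the same carbon. As far as these compounds go, it is also open whether a nitrile, an amine or a carboxylic acid there would give a number within the scatter of compound 1, or whether the same substituent on another ring carbon would give a step of similar size.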